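The compounds below may be only part of what the source reports. "The series", "measured", "known", "first", "only" and "open" are said of these compounds alone.

Among the measured compounds shown here, compound 1, `C=C1CC[C@@H]2[C@](C)(COC(C)=O)[C@H](OC(C)=O)CC[C@@]2(C)[C@H]1CC(Nc1ccc(S(=O)(=O)Nc2nccs2)cc1)C1=CCOC1=O`, stands as the higher of the two numbers so far recorded in a functional assay on KM12 cells (Homo sapiens) for inhibition, read by sulforhodamine B assay, with a stated time of 48 h (on this read-out higher numbers stand for weaker inhibition of growth and lower numbers for stronger inhibition of growth), giving 7570 nM. For the measured compounds named here, its only measured neighbour is compound 2, `C=C1CC[C@@H]2[C@](C)(COC(C)=O)[C@H](OC(C)=O)CC[C@@]2(C)[C@H]1CC(Nc1ccc(S(=O)(=O)Nc2ccc(Cl)nn2)cc1)C1=CCOC1=O`, which in this assay gives 1700 nM; the step is a 4.5-fold lower number from compound 1 to compound 2 (0.65 log units; beyond the scatter), the change being 6-chloropyridazin-3-yl in place of 1,3-thiazol-2-yl on a sulfonamide nitrogen. Compound 3, `C=C1CC[C@@H]2[C@](C)(COC(C)=O)[C@H](OC(C)=O)CC[C@@]2(C)[C@H]1CC(Nc1ccc(S(=O)(=O)Nc2ncccn2)cc1)C1=CCOC1=O`, differs from compound 1 at the same sulfonamide nitrogen: pyrimidin-2-yl in place of 1,3-thiazol-2-yl on a sulfonamide nitrogen. Going by the values given here, the step of a 4.5-fold lower number from compound 1 to compound 2 (0.65 log units; beyond the scatter) is the one measurement that bears on this change, since it also exchanges 1,3-thiazol-2-yl for a six-membered aromatic ring with two hetero atoms at that nitrogen, and it lowered the number modestly. A move of similar kind but somewhat smaller is therefore expected for compound 3, namely a 2.2-fold lower number from compound 1 to compound 3 (0.34 log units; beyond the scatter). Compound 3 is thus estimated to give 3500 nM in this assay, within a range from 1200 nM to 10000 nM.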

Compound 3, concentration for 50% growth inhibition: 2330 nM
Compound 3: middle estimate off by 1.5-fold (0.18 log units), on the high side; measured number inside the range.
By their numbers in this assay, from the lowest: compounds 2 and 3 (each within the scatter of the next); then compound 1.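

In this assay a second six-membered aromatic ring with 2 hetero atoms on the sulfonamide nitrogen also beats 1,3-thiazol-2-yl, with a 3.2-fold lower number from compound 1 to compound 3 (0.51 log units; beyond the scatter) in this exchange, so the gain seen with 6-chloropyridazin-3-yl is not confined to that one group. Pyrimidin-2-yl and 6-chloropyridazin-3-yl cannot be told apart, with a 1.4-fold higher number from compound 2 to compound 3 (0.14 log units; within the scatter) in a change that alters the ring and removes the chloro group. Nothing at hand explains why either six-membered ring differs from 1,3-thiazol-2-yl.

The compounds shown leave open whether a phenyl or pyridin-2-yl ring on this nitrogen would match these two groups. They also leave open whether a methoxy group or an amine on the six-membered ring would move the number further.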